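The source may hold more compounds than are shown below. What is called first, only, known or untested is meant among the compounds shown, and "the series" means these compounds.

Working notes on the series. In a functional assay on HL-60 cells (Homo sapiens) for antiproliferative activity, read by XTT assay, with a stated time of 72 h (on this read-out lower numbers stand for stronger inhibition and higher numbers for weaker inhibition), compound 1 `C#Cc1cn([C@@H]2O[C@H](CO)[C@@H](O)[C@H]2O)c2ncnc(NC)c12` gives 9060 nM, a true number. Compound 2 `CN(C)c1ncnc2c1c(-c1cc3ccccc3o1)cn2[C@@H]1O[C@H](CO)[C@@H](O)[C@H]1O` has no number in this assay, and its entry is a limit of the assay: compound 2 reads > 20000 nM. Its position is therefore known only as that limit.

Compound 3 `C#Cc1cn([C@@H]2O[C@H](CO)[C@@H](O)[C@H]2O)c2ncnc(N(C)C)c12` comes from compound 2 by one change, with ethynyl in place of 1-benzofuran-2-yl on an aromatic carbon, two ring bonds from the ring nitrogen (ethynyl in place of 1-benzofuran-2-yl on an aromatic carbon).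

Among the measured compounds shown here, no pair of measured compounds differs in one place only, so no measured step sets the size of this change. The expectation rests on compound 1, which also carries ethynyl and gives 9060 nM. A move towards stronger inhibition is expected, of modest size, though its starting point is only a limit. The estimated change is an at least 2.0-fold lower number from compound 2 to compound 3 (0.30 log units; that floor lies within the scatter). For compound 3 the expected value is 10000 nM, within an estimated range of 3000 nM to 20000 nM.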

Compound 3, half-maximal inhibitory concentration: 290 nM
For compound 3 the middle estimate is 34-fold (1.54 log units) above the measured one, and the stated range ends above it.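

In this assay, among the compounds shown here, ethynyl in place of 1-benzofuran-2-yl on the aromatic carbon two ring bonds from the ring nitrogen gives an at least 68-fold lower number from compound 2 to compound 3 (1.83 log units; beyond the scatter), the first reading of what this position does when the nitrogen on the aromatic ring carries two methyl groups. The entry for compound 2 is a limit of the assay, so this step sets only a floor on the size of the change: the limit of > 20000 nM in this assay, at which 1 of the 3 values shown sits.

With ethynyl held fixed, methyl in place of hydrogen on the nitrogen on the aromatic ring gives a 31-fold lower number from compound 1 to compound 3 (1.49 log units; beyond the scatter), so ethynyl at this carbon does not alone set the level, and the strong value appears only with the second methyl on that nitrogen.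

The compounds shown leave open whether the gain belongs to ethynyl itself or to the loss of 1-benzofuran-2-yl, since a plain hydrogen, a chlorine atom or a longer alkyne chain at that carbon would separate the two. They also leave open how far the nitrogen on the aromatic ring can go beyond methyl, for instance to ethyl groups or to a pyrrolidine ring.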